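The compounds below may be only part of what the source reports. "The series", "measured", "known", "first", "only" and "open" are said of these compounds alone.

Measured compounds in an in vitro assay on Sf9 cells for inhibition of leukotriene A-4 hydrolase (Homo sapiens), read by immunoassay, with stated times of 10 min and 30 min; a lower number here means a stronger inhibitor, a higher number a weaker inhibitor:
- compound 1 `c1ccc2sc(Oc3ccc4c(CN5CCCCC5)coc4c3)nc2c1` gives 67 nM
- compound 2 `CC(=O)NC1CCN(Cc2coc3cc(Oc4nc5ccccc5s4)ccc23)CC1` gives 26 nM
- compound 3 `CC(=O)NC1CCN(Cc2coc3cc(Oc4nc5ncccc5s4)ccc23)CC1` gives 3.7 nM

Compound 2 stands second highest of the three numbers in this assay: compound 1 sits above it by a 2.6-fold lower number from compound 1 to compound 2 (0.41 log units; beyond the scatter), and compound 3 sits below it by a 7.0-fold lower number from compound 2 to compound 3 (0.85 log units; beyond the scatter). The step from compound 1 to compound 2 is the one that bears on the change now considered, since it concerns the same saturated ring carbon; it was a modest gain on adding acetamido. The step from compound 2 to compound 3 concerns the other end of the molecule and does not bear on it.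

Compound 4 `O=C1CCCN1C1CCN(Cc2coc3cc(Oc4nc5ccccc5s4)ccc23)CC1` differs from compound 2 by 2-oxopyrrolidin-1-yl in place of acetamido on a saturated ring carbon. Among the compounds with values here, no measured pair shows what a ring in place of an open amide at this position does, so the expectation rests only on the modest gain seen for acetamido over hydrogen. The step from compound 2 to compound 4 in this assay is expected to be a 1.2-fold higher number from compound 2 to compound 4 (0.06 log units; within the scatter), close to none beyond the scatter. Compound 4 is therefore estimated at 30 nM in this assay, with a range from 10 nM to 90 nM.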

Compound 4, half-maximal inhibitory concentration: 58 nM
For compound 4 the middle estimate is 1.9-fold (0.29 log units) below the measured one; measured number inside the range.
By their numbers in this assay, from the lowest: compound 3; then compound 2; then compounds 4 and 1 (each within the scatter of the next).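

In this assay the gain seen for acetamido does not carry over to 2-oxopyrrolidin-1-yl on the same saturated ring carbon: there is a 2.2-fold higher number from compound 2 to compound 4 (0.35 log units; beyond the scatter) and, against the compound with hydrogen at this carbon, a 1.2-fold lower number from compound 1 to compound 4 (0.06 log units; within the scatter) and so no separation between the two. The change removes the hydrogen-bond donor and adds a five-membered ring in one step, and this pair cannot tell those two differences apart. Nothing in the data gives a reason for the step.

Still open, going by these compounds, is how an open chain longer than acetamido, a primary amine or a carboxylic acid would compare on this carbon. Also open, on these data alone, is whether 2-oxopyrrolidin-1-yl gives the same step on the core of compound 3.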